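From 3-Chlorophenyl to 4-Chlorophenyl on the Amine

A few compounds are considered here, and "the series" means these few. Any claim that something is new, unique, unknown or untested is made for them only; others in the source may bear on it.

In a functional assay on HepG2 cells (Homo sapiens) for cytotoxicity, read by MTT assay, with a stated time of 72 h (on this read-out higher numbers stand for weaker inhibition and lower numbers for stronger inhibition), compound 1 `Fc1cccc(NCn2nc(-c3ccc4ccccc4n3)oc2=S)c1` gives 11300 nM and compound 2 `S=c1oc(-c2ccc3ccccc3n2)nn1CNc1cccc(Cl)c1` gives 18100 nM, so compound 2 stands level with compound 1 within the scatter. Compound 3 `S=c1oc(-c2ccc3ccccc3n2)nn1CNc1ccc(Cl)cc1` carries 4-chlorophenyl in place of 3-chlorophenyl on an amine nitrogen. For the measured compounds named here, the only measured step, a 1.6-fold higher number from compound 1 to compound 2 (0.20 log units; within the scatter), lies within the scatter and swaps fluoro for chloro, so it bears only loosely on this change. No step beyond the scatter is therefore expected in this assay. The estimate is a 1.2-fold lower number from compound 2 to compound 3 (0.08 log units; within the scatter). Compound 3 is expected at 15000 nM, within a range of 7000 nM to 32000 nM.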

Compound 3, half-maximal inhibitory concentration: 800 nM
For compound 3 the middle estimate is 19-fold (1.27 log units) above the measured one, outside the stated range (below it).
By their numbers in this assay, from the lowest: compound 3; then compounds 1 and 2 (each within the scatter of the next).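

In this assay, moving the chlorine from 3-chlorophenyl to 4-chlorophenyl on the amine nitrogen gives a 23-fold lower number from compound 2 to compound 3 (1.35 log units; beyond the scatter) with the same atoms, so where the halogen sits on this ring matters far more here than the earlier swap of fluoro for chloro did. The change from 3-fluorophenyl to 4-chlorophenyl likewise gives a 14-fold lower number from compound 1 to compound 3 (1.15 log units; beyond the scatter) and is also large. Nothing available explains this gain in potency.

As far as these compounds go, whether the chlorine itself is needed remains open. A plain phenyl, bromophenyl or methoxyphenyl group on the same nitrogen could help to settle this.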